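Solubility notes: hydroxamic acid series, step to compound 4

This account rests on a few compounds, and the source may have more. Where it says the series, first, only, none or still open, it means among the compounds named here.

Measured compounds:
compound 1 `C#CCNC(=O)C[C@H](NC(=O)c1ccc(C#Cc2ccccc2)cc1)C(=O)NO` gives 8000 nM
compound 2 `O=C(N[C@@H](CO)C(=O)NO)c1ccc(C#Cc2ccccc2)cc1` gives 28000 nM
compound 3 `COCCNC(=O)C[C@H](NC(=O)c1ccc(C#Cc2ccccc2)cc1)C(=O)NO` gives 78000 nM

In a physicochemical assay for solubility (on this read-out higher numbers stand for higher solubility and lower numbers for lower solubility), compound 2 stands second highest of the three numbers. Its nearest neighbour is compound 3, reached by a 2.8-fold higher number from compound 2 to compound 3 (0.44 log units; beyond the scatter); the furthest is compound 1, from which a 3.5-fold higher number from compound 1 to compound 2 (0.54 log units; beyond the scatter) leads up to compound 2. Compound 1 and compound 3 are separated by a 9.8-fold higher number from compound 1 to compound 3 (0.99 log units; beyond the scatter).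

Compound 4 `CC(NC(=O)c1ccc(C#Cc2ccccc2)cc1)C(=O)NO` is not yet measured. It differs from compound 2 by a group of 6 heavy atoms (3 carbon, 1 nitrogen, 2 oxygen; no ring) in place of a group of 7 heavy atoms (3 carbon, 1 nitrogen, 3 oxygen; no ring), on an amide-type nitrogen. For the measured compounds named here, none of the measured steps removes this group; the measured steps all exchange substituents two bonds along the chain or on the carbon bound to the amide-type nitrogen, and all of them are modest rises. Going by the values given here, the change to compound 4 has no direct counterpart, so only a modest step at most is expected, most likely downward or within the scatter, written as a 1.9-fold lower number from compound 2 to compound 4 (0.27 log units; within the scatter).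

Compound 4 is therefore estimated at 15000 nM, with a range from 5000 nM to 45000 nM.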

Compound 4, solubility: 29000 nM
The estimate for compound 4 lay 1.9-fold (0.29 log units) below the measured number; low and high end bracket the measured number.
By their numbers in this assay, from the lowest: compound 1; then compounds 2 and 4 (each within the scatter of the next); then compound 3.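

In this assay, for the compounds shown here, 1-(hydroxycarbamoyl)ethyl in place of the group of 7 heavy atoms on an amide-type nitrogen gives a 1.0-fold higher number from compound 2 to compound 4 (0.02 log units; within the scatter), the first step that lies within the scatter. At this place, a group with 2 hydrogen-bond donors and 2 acceptors thus reads the same as one with 3 of each, whereas the steps among compounds 1, 2 and 3 all lie beyond the scatter. No measurement is available that bears on this result.

The group leaving compound 2 carries 1 defined stereocentre and the group entering compound 4 carries none, so this pair cannot separate that difference from the change in oxygen count. On these data alone, whether an amine, a carboxylic acid or a longer chain at this place would also stay within the scatter of compound 2 remains open.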